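The source may hold more compounds than are shown below. What is called first, only, known or untested is meant among the compounds shown, and "the series" means these compounds.

Working notes on the series. Among the compounds with values here, compound 1 `COC(C)CO[C@H](CC=C(C)C)C1=CC(=O)c2c(O)ccc(O)c2C1=O` is the reference; in a functional assay on DU-145 cells (Homo sapiens) for cytotoxicity, read by MTT assay (a higher number here means a weaker inhibitor, a lower number a stronger inhibitor), compound 1 gives 16600 nM, the lowest of the two numbers so far. Compound 2 `CCCCC(C)(O)CC(=O)O[C@H](CC=C(C)C)C1=CC(=O)c2c(O)ccc(O)c2C1=O` in this assay gives 76500 nM, and the step of a 4.6-fold higher number from compound 1 to compound 2 (0.66 log units; beyond the scatter) is the only measured one bearing on the change to compound 3 `CCC(O)(CC)CC(=O)O[C@H](CC=C(C)C)C1=CC(=O)c2c(O)ccc(O)c2C1=O`, which is (2-ethyl-2-hydroxybutyl)carbonyl in place of 2-methoxypropyl on an oxygen on a saturated carbon. Within the data shown here, that change closely resembles the one to compound 2, so a higher number beyond the scatter is expected, of about a 3.6-fold higher number from compound 1 to compound 3 (0.56 log units; beyond the scatter). Compound 3 is therefore estimated at 60000 nM in this assay, within 25000 nM to 150000 nM.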

Compound 3, half-maximal inhibitory concentration: 67000 nM
Compound 3: the middle estimate sits 1.1-fold (0.05 log units) below what was measured; the range from low to high includes it.
By their numbers in this assay, from the lowest: compound 1; then compounds 3 and 2 (each within the scatter of the next).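

The second (2-ethyl-2-hydroxybutyl)carbonyl result shows that the rise seen with compound 2 is not confined to one chain: in this assay, the step is a 4.0-fold higher number from compound 1 to compound 3 (0.61 log units; beyond the scatter) for this replacement on the oxygen. Exchanging 1-hydroxy-1-methylpentyl for 1-ethyl-1-hydroxypropyl gives a 1.1-fold lower number from compound 2 to compound 3 (0.06 log units; within the scatter) in this assay, so these two chains are not told apart here. No supporting measurement offers a reason for either step.

The compounds shown do not separate the contribution of the carbonyl from that of the hydroxyl. As far as these compounds go, it also remains open whether an acetyl group or an amine-bearing chain in place of 2-methoxypropyl would give a lower number than compound 1.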